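Solubility series: alkynyl to alkenyl at the quinolone carbon

The source may hold more compounds than are shown below. What is called first, only, known or untested is meant among the compounds shown, and "the series" means these compounds.

Working notes on the shared core, measured in a physicochemical assay for solubility, read by HPLC, at pH 7.4; a higher number here means a more soluble compound, a lower number a less soluble compound. Compound 1 `CCCCCCCc1c(C)[nH]c2cc(OC)c(Cl)cc2c1=O` carries a heptyl chain; in this assay compound 1 gives < 2000 nM, which is a limit of the assay rather than a number. Compound 2 `COc1cc2[nH]c(C)c(C3CCCCC3)c(=O)c2cc1Cl` carries cyclohexyl and gives 5000 nM. Compound 3 `CCCCC#Cc1c(C)[nH]c2cc(OC)c(Cl)cc2c1=O` carries hex-1-yn-1-yl; for compound 3 this assay gives > 20000 nM, again a limit and not a number. Compound 3 thus stands at the upper end of what has been seen, the size of its lead being open because the limit of > 20000 nM in this assay, at which 1 of the 3 values shown sits, and because of the limit of < 2000 nM in this assay, at which 1 of the 3 values shown sits.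

Compound 4 `C=C(CCCCC)c1c(C)[nH]c2cc(OC)c(Cl)cc2c1=O` is next: a group of 7 heavy atoms (7 carbon; no ring) in place of a group of 6 heavy atoms (6 carbon; no ring), on an aromatic carbon. The entering chain has 1 double bond outside aromatic rings where hex-1-yn-1-yl had 1 triple bond, and in carbon count it matches the heptyl of compound 1 rather than the hex-1-yn-1-yl of compound 3. Going by the values given here, the steps that bear on this are an at least 10-fold higher number from compound 1 to compound 3 (1.00 log units; beyond the scatter) and an at least 4.0-fold higher number from compound 2 to compound 3 (0.60 log units; beyond the scatter), both running toward hex-1-yn-1-yl and both beyond the scatter. Reversing part of that change is expected to move the number down, with a step estimated as an at least 4.0-fold lower number from compound 3 to compound 4 (0.60 log units; beyond the scatter). Compound 4 is therefore estimated at 5000 nM, within 1500 nM to 15000 nM.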

Compound 4, solubility: 2000 nM
Beside the measured number, compound 4's estimate is 2.5-fold (0.40 log units) above it; the range from low to high includes it.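

In this assay, the chain of compound 4, with 1 double bond outside aromatic rings and 7 carbon, does not keep the standing of the hex-1-yn-1-yl chain at this aromatic carbon: an at least 10-fold lower number from compound 3 to compound 4 (1.00 log units; beyond the scatter). As far as these compounds go, the value of compound 3 is a limit, so the full size of this step stays open. The new chain also falls short of the cyclohexyl group at the same place, a 2.5-fold lower number from compound 2 to compound 4 (0.40 log units; beyond the scatter), so among the compounds shown, a double bond in an open chain does not place compound 4 above the ring-bearing compound 2. Between the two open chains with 7 carbon the step reads a number no lower from compound 1 to compound 4 (the limit leaves the size open) and its size cannot be read: the limit of < 2000 nM in this assay, at which 1 of the 4 values shown sits.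

From the compounds shown here alone, compound 3 and compound 4 differ both in the unsaturated bond and in carbon count and attachment, so what the drop follows stays open; a hex-1-en-1-yl or hept-1-yn-1-yl chain would separate these changes. Also open, going by these compounds, is how a chain ending in an amine or a carboxylic acid at this aromatic carbon would read in this assay.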